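Adding a methoxy link to compound 2

The source may report more compounds than this note shows. Statements on the series, on what has been measured and on what is new or still open speak of the compounds shown alone.

In a functional assay on the whole organism with Cavia porcellus as the target (on this read-out higher numbers stand for an effect only at larger amounts of compound and lower numbers for an effect already at smaller amounts), compound 1 (`c1cc(OCc2ccc(-c3nn[nH]n3)cc2)cc(OCc2ccc3ccccc3n2)c1`) gives 6.5 mg/kg and compound 2 (`c1cc(COc2ccc(OCc3ccc4ccccc4n3)cc2)cc(-c2nn[nH]n2)c1`) gives 2 mg/kg as the lower of the two numbers, a gap beyond the usual scatter of repeat measurements. These two compounds differ in more than one place, so neither value isolates a single change. Compound 3 (`c1cc(COc2ccc(OCc3ccc4ccccc4n3)cc2)cc(OCc2nn[nH]n2)c1`) keeps the rest of compound 2 but carries (2H-tetrazol-5-yl)methoxy in place of 2H-tetrazol-5-yl on an aromatic carbon is the full count of that swap. Going by the values given here, no measured pair shows this change, so the forecast is loose. Among the compounds with values here, compound 2 holds the lowest number so far at 2 mg/kg and compound 1 reaches 6.5 mg/kg in the same family, which suggests a drift upward more than a further fall. An estimated 2.0-fold higher number from compound 2 to compound 3 (0.30 log units; within the scatter) seems likely, toward a higher number and near the edge of the scatter. For compound 3 the estimated value is 4 mg/kg with an expected range from 1.2 mg/kg to 13 mg/kg in this assay once it is measured.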

Compound 3, dose for half-maximal effect: 2.8 mg/kg
The estimate for compound 3 lay 1.4-fold (0.15 log units) above the measured number, within the range that was stated.
By their numbers in this assay, from the lowest: compounds 2 and 3 (each within the scatter of the next); then compound 1.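

In this assay, (2H-tetrazol-5-yl)methoxy in place of 2H-tetrazol-5-yl on an aromatic carbon gives a 1.4-fold higher number from compound 2 to compound 3 (0.15 log units; within the scatter) and so stays within what repeat measurements would scatter. Going by these compounds alone, at this place, meta to a large group, the tetrazole ring can therefore sit on a methoxy link with no difference this read-out can resolve, and this is the first comparison here that isolates a single change, as compound 1 and compound 2 differ in more than one place. Nothing at hand explains why the swap leaves the read-out within the scatter.

From the compounds shown here alone, what a carboxylic acid at this same place would give remains open, as does the result of a longer chain carrying the tetrazole. Also open, going by these compounds, is whether the methoxy link would behave the same way at any other place on the ring.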